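Quinone amino-acid series: branching the acid side chain

The source may hold more compounds than are shown below. What is called first, only, known or untested is meant among the compounds shown, and "the series" means these compounds.

The shared core of compound 1 `CC1=CCC[C@H]2[C@](C)(CC3=CC(=O)C=C(N[C@@H](C(=O)O)C(C)C)C3=O)[C@@H](C)CC[C@]12C` carries an amine nitrogen bearing an acid-containing chain; in a functional assay on Fem-X cells (Homo sapiens) for cytotoxicity, read by MTT assay, with a stated time of 72 h (a higher number here means a weaker inhibitor, a lower number a stronger inhibitor), compound 1 gives 11400 nM. Compound 2 `CC1=CCC[C@H]2[C@](C)(CC3=CC(=O)C=C(NCCC(=O)O)C3=O)[C@@H](C)CC[C@]12C` gives 20200 nM, the upper end of the three numbers shown, yet its gap to compound 1 and to compound 3 `C[C@H](NC1=CC(=O)C=C(C(C)(C)C)C1=O)C(=O)O`, which gives 20100 nM, stays within the scatter. Compound 4 `CC1=CCC[C@H]2[C@](C)(CC3=CC(=O)C=C(N[C@@H](CC(C)C)C(=O)O)C3=O)[C@@H](C)CC[C@]12C` differs from compound 2 by 1-carboxy-3-methylbutyl in place of 2-carboxyethyl on an amine nitrogen. For the measured compounds named here, the only step that bears on this is a 1.8-fold higher number from compound 1 to compound 2 (0.25 log units; within the scatter), which runs the opposite way, from a branched acid to the straight one. Compound 4 is therefore expected to sit near compound 1, with a 1.7-fold lower number from compound 2 to compound 4 (0.23 log units; within the scatter) unlikely to exceed the scatter. The estimate for compound 4 is 12000 nM, within 5000 nM to 30000 nM.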

Compound 4, half-maximal inhibitory concentration: 10900 nM
The estimate for compound 4 lay 1.1-fold (0.04 log units) above the measured number; the measured number falls inside the stated range.
By their numbers in this assay, from the lowest: compounds 4, 1, 3 and 2 (each within the scatter of the next).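

On the amine nitrogen, 1-carboxy-3-methylbutyl in place of 2-carboxyethyl gives in this assay (a 1.9-fold lower number from compound 2 to compound 4 (0.27 log units; within the scatter)), so a second branched acid chain, like 1-carboxy-2-methylpropyl, stays within the scatter of the straight chain. 1-Carboxy-3-methylbutyl in place of 1-carboxy-2-methylpropyl gives (a 1.0-fold lower number from compound 1 to compound 4 (0.02 log units; within the scatter)), so the change between these two branched chains also shows no readable difference. No supporting evidence bears on these results.

Open, on these data alone, is whether a methyl ester in place of the carboxylic acid, or a longer straight chain on this nitrogen, would give a step beyond the scatter.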